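The source may hold more compounds than are shown below. What is called first, only, known or untested is meant among the compounds shown, and "the series" means these compounds.

Measured compounds:
Compound 1, `C/N=C(/NC#N)NCCCn1nc(-c2ccccc2)ccc1=O`: in a functional assay on the whole organism with Rattus norvegicus as the target (on this read-out lower numbers stand for an effect already at smaller amounts and higher numbers for an effect only at larger amounts of compound), compound 1 gives 78.1 mg/kg.
Compound 3, `CC/N=C(/NC#N)NCCCn1nc(-c2ccccc2)ccc1=O`: in this assay compound 3 gives 88.5 mg/kg.
Compound 2, `C/N=C(/NC#N)NCCCCCCn1nc(-c2ccccc2)ccc1=O`: in this assay compound 2 returns only a limit, > 100 mg/kg.

Compound 2 thus stands at the upper edge of what this assay reports, as the limit of > 100 mg/kg in this assay, at which 1 of the 3 values shown sits; no number is known for it, only that the dose lies beyond the reported range. Compound 4, `CC/N=C(/NC#N)NCCCCCCn1nc(-c2ccccc2)ccc1=O`, differs from compound 2 by methyl in place of hydrogen on a saturated chain carbon bound to a double-bonded nitrogen. Among the compounds with values here, the one measured step of the same kind, a 1.1-fold higher number from compound 1 to compound 3 (0.05 log units; within the scatter), lies within the scatter, so the change at this position has so far produced no shift that can be separated from repeat-measurement noise. The same is therefore expected for the step that the limit leaves unreadable from compound 2 to compound 4 in this assay: no change beyond the scatter. Compound 4 is accordingly expected to give about 150 mg/kg, with a range from 70 mg/kg to 400 mg/kg, and most likely to return only a limit again, as compound 2 did.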

Compound 4, dose for half-maximal effect: > 100 mg/kg
Compound 4: no number, only a limit (the forecaster's own chance of this, stated with the estimate: 75%); the middle value lies beyond the limit too.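

In this assay compound 2 and compound 4 each return only a limit, so no step can be read between them: the limit of > 100 mg/kg in this assay, at which 2 of the 4 values shown sit. Still open, on these data alone, is where the true doses of compound 2 and compound 4 lie, and whether methyl in place of hydrogen shifts them at all.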